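From Methoxy to Nitro on a Shared Core

A few compounds are considered here, and "the series" means these few. Any claim that something is new, unique, unknown or untested is made for them only; others in the source may bear on it.

Of the compounds shown here, two have been tested in a functional assay on the whole organism (strain Wister albino) for inhibition, with Rattus norvegicus as the target, read by paw edema, with stated times of 30 min and 3 h, at a dose of 10 mg/kg by the oral route; on this read-out higher numbers stand for more inhibition at the one dose given (going by the name of the read-out) and lower numbers for less inhibition. Compound 1 `CC(C)Cc1ccc(C(C)c2nn(CN3CCN(c4ccc(Cl)cc4)CC3)c(=S)o2)cc1` gives 76.6% in this assay. Compound 2 `COc1ccc(N2CCN(Cn3nc(Cc4ccc(SC)cc4)oc3=S)CC2)cc1` gives 33.7% in this assay, the lower of the two numbers, and its gap to compound 1 lies beyond the scatter. Compound 1 and compound 2 differ in several places, so no single change can be tied to that gap. Compound 3 `CSc1ccc(Cc2nn(CN3CCN(c4ccc([N+](=O)[O-])cc4)CC3)c(=S)o2)cc1` has not yet been measured; it differs from compound 2 in one place: nitro in place of methoxy on an aromatic carbon. Within the data shown here, no measured step covers a comparable change, so only a small step is expected, a number 6.3 percentage points higher from compound 2 to compound 3 (within the scatter), likely within the scatter in either direction. Compound 3 is expected to give about 40% in this assay, in a range from 22% to 60%.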

Compound 3, a percentage reported as inhibition, in the whole organism at one dose (the size of the read-out at that dose, not a potency): 56.6%
The estimate for compound 3 lay 16.6 percentage points below the measured number, within the range that was stated.
By their numbers in this assay, from the lowest: compound 2; then compound 3; then compound 1.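

Going from 4-methoxyphenyl to 4-nitrophenyl is the first change in this assay that can be read on its own, and it gives a number 22.9 percentage points higher from compound 2 to compound 3 (beyond the scatter). The group at this place, para to a large group, therefore matters for this read-out, at least in this one pair. Nothing at hand explains why the number moves.

From the compounds shown here alone, whether an amine or a carboxylic acid at this place would give a higher or a lower number remains open. So does whether the same change would carry over to the core of compound 1.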